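Moving the benzyl substituent: from chloro to methyl

A few compounds are considered here, and "the series" means these few. Any claim that something is new, unique, unknown or untested is made for them only; others in the source may bear on it.

The three measured compounds share one core and differ only in the aryl group on a saturated chain carbon bound to a sulfur. Compound 1 `Cc1cc(S(=O)(=O)/N=C(\N)n2nccc2-c2ccccc2)c(SCc2ccc(Cl)cc2)cc1Cl` gives 3000 nM in a functional assay on HeLa cells (Homo sapiens) for cytotoxicity, read by MTT assay, with a stated time of 72 h; a lower number here means a stronger inhibitor, a higher number a weaker inhibitor. Compound 2 `Cc1cc(S(=O)(=O)/N=C(\N)n2nccc2-c2ccccc2)c(SCc2ccccc2Cl)cc1Cl` gives 19000 nM, and compound 3 `Cc1cc(S(=O)(=O)/N=C(\N)n2nccc2-c2ccccc2)c(SCc2cccc(Cl)c2)cc1Cl` gives 10000 nM. Compound 3 thus sits second highest of the three, close to compound 2 and separated from compound 1 by a step beyond the scatter, since a 3.3-fold higher number from compound 1 to compound 3 (0.52 log units; beyond the scatter).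

Compound 4 `Cc1ccc(CSc2cc(Cl)c(C)cc2S(=O)(=O)/N=C(\N)n2nccc2-c2ccccc2)cc1` carries the change (4-methylphenyl in place of 3-chlorophenyl on a saturated chain carbon bound to a sulfur). Among the compounds with values here, two measured steps bear on it. Compound 1, which carries 4-chlorophenyl, the closest measured relative of 4-methylphenyl, is favoured over the other two: a 6.3-fold higher number from compound 1 to compound 2 (0.80 log units; beyond the scatter) and a 3.3-fold higher number from compound 1 to compound 3 (0.52 log units; beyond the scatter). Within the data shown here, no measured pair tests chloro against methyl on this ring, so that part of the change has no direct support. Because compound 1 stands at 3000 nM, a lower number than compound 3 is expected for compound 4, most likely a modest drop, a 2.0-fold lower number from compound 3 to compound 4 (0.30 log units; within the scatter), with wide uncertainty. Compound 4 is estimated at 5000 nM, within a range of 1500 nM to 16000 nM.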

Compound 4, half-maximal inhibitory concentration: 17000 nM
Beside the measured number, compound 4's estimate is 3.4-fold (0.53 log units) below it; the measured number lies above the stated range.
By their numbers in this assay, from the lowest: compound 1; then compounds 3, 4 and 2 (each within the scatter of the next).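

Within the data shown here, the only step that changes chloro to methyl with the place on the ring held constant is a 5.7-fold higher number from compound 1 to compound 4 (0.75 log units; beyond the scatter) in this assay, so the lower number of compound 1 does not carry over from 4-chlorophenyl to 4-methylphenyl. Compound 4 instead groups with the two other chloro isomers, with a 1.7-fold higher number from compound 3 to compound 4 (0.23 log units; within the scatter) and a 1.1-fold lower number from compound 2 to compound 4 (0.05 log units; within the scatter), which leaves compound 1 as the only one of the four set apart, and this position therefore responds to the identity of the group as well as to where it sits on the ring. Nothing available here accounts for the gap between 4-chlorophenyl and 4-methylphenyl.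

The compounds shown leave open whether the lower number of compound 1 is particular to chloro, or whether 4-fluorophenyl, 4-bromophenyl or 4-methoxyphenyl at the same place would stand with compound 1 or with compound 4. They also leave open where unsubstituted phenyl would fall, which would show whether 4-chlorophenyl lowers the number or the other groups raise it.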